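Para substitution on the benzylidene ring of the shared core

The source may hold more compounds than are shown below. What is called first, only, known or untested is meant among the compounds shown, and "the series" means these compounds.

Compound 1 (`CC1=CC[C@H](C(C)(C)NC(=S)N/N=C/c2ccc(O)cc2)CC1`) carries a 4-hydroxyphenyl on the carbon with a double bond to nitrogen. In a functional assay on MCF7 cells (Homo sapiens) for inhibition, read by sulforhodamine B assay, with a stated time of 48 h (a higher number here means a weaker inhibitor of growth, a lower number a stronger inhibitor of growth), compound 1 gives > 100000 nM, which is a limit of the assay and not a number, so compound 1 stands only at the weak end of what is shown. Compound 2 (`CC1=CC[C@H](C(C)(C)NC(=S)N/N=C/c2ccccc2O)CC1`) differs by 2-hydroxyphenyl in place of 4-hydroxyphenyl, and in this assay compound 2 gives 17500 nM. For the measured compounds named here, the one measured step, an at least 5.7-fold lower number from compound 1 to compound 2 (0.75 log units; beyond the scatter), rests on the limit of > 100000 nM in this assay, at which 1 of the 2 values shown sits, and concerns only where the hydroxy sits. Compound 3 (`CC1=CC[C@H](C(C)(C)NC(=S)N/N=C/c2ccc(Cl)cc2)CC1`) differs from compound 1 by chloro in place of hydroxy on an aromatic carbon. Going by the values given here, no measured step exchanges hydroxy for chloro, so this change has no direct precedent; the only comparison available keeps the hydroxy and changes its position. The expected step is therefore an at least 1.6-fold lower number from compound 1 to compound 3 (0.22 log units; that floor lies within the scatter) in this assay, of uncertain direction and not clearly beyond the scatter. Compound 3 is expected to give 60000 nM in this assay, with a range from 15000 nM to 200000 nM.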

Compound 3, concentration for total growth inhibition: > 100000 nM
Compound 3: no number, only a limit; the forecaster's own chance of this, stated with the estimate: 45%; at least 1.6-fold (0.22 log units) between middle value and limit.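

In this assay compound 3 gives > 100000 nM, which is a limit of the assay and not a number, so a second group at the position para to a large group, here chloro in place of hydroxy, also yields no number. The step between compound 1 and compound 3 cannot be read, because both values stand at the same limit: the limit of > 100000 nM in this assay, at which 2 of the 3 values shown sit.

For the compounds shown here, the one readable new step is an at least 5.7-fold higher number from compound 2 to compound 3 (0.75 log units; beyond the scatter), but it changes the group and its place on the ring together, so it does not separate the effect of chloro from that of moving the substituent.

Open, from the compounds shown here alone, is whether chloro at the ring position that carries the hydroxy in compound 2 gives a number in this assay, which would separate the group from its place. Also open, going by these compounds, is whether any other group at the position para to a large group, such as an amine, a methoxy group or a carboxylic acid, gives a number there at all.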